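The source may hold more compounds than are shown below. What is called first, only, known or untested is meant among the compounds shown, and "the series" means these compounds.

Working notes on the series. In a functional assay on HepG2 cells (Homo sapiens) for inhibition, read by sulforhodamine B assay, with a stated time of 3 days (on this read-out higher numbers stand for weaker inhibition and lower numbers for stronger inhibition), compound 1 (`O=C1Nc2ccc(F)cc2/C1=C\C(=O)c1ccc(O)cc1F`) gives 3440 nM and compound 2 (`O=C1Nc2ccc(F)cc2/C1=C\C(=O)c1ccc[nH]1`) gives 3120 nM. These two values lie within the scatter of each other, so compound 2 stands level with compound 1. Compound 3 (`O=C1Nc2ccc(F)cc2/C1=C\C(=O)c1cccs1`) has not yet been measured in this assay. Its structure differs from that of compound 2 as follows: thiophen-2-yl in place of 1H-pyrrol-2-yl on a carbonyl carbon. Thiophen-2-yl thus stands in place of 1H-pyrrol-2-yl on a carbonyl carbon. For the measured compounds named here, no measured step between compounds differing in one place is available for this change. Going by the values given here, the only guide is the level shared by compound 1 at 3440 nM and compound 2 at 3120 nM, so no change beyond the scatter is expected in either direction. The expected step is a 1.0-fold lower number from compound 2 to compound 3 (0.02 log units; within the scatter). For compound 3 the estimated value is 3000 nM, with an expected range of 1100 nM to 8000 nM.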

Compound 3, half-maximal inhibitory concentration: 8780 nM
Estimate against measurement, compound 3: 2.9-fold (0.47 log units) below; the whole stated range lies below it.
By their numbers in this assay, from the lowest: compounds 2 and 1 (each within the scatter of the next); then compound 3.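

In this assay this place on a carbonyl carbon proves sensitive to which five-membered aromatic ring it carries: thiophen-2-yl in place of 1H-pyrrol-2-yl gives a 2.8-fold higher number from compound 2 to compound 3 (0.45 log units; beyond the scatter) and thus weaker inhibition, a modest step. The two groups match in heavy-atom count and ring type, and differ in sulfur for nitrogen and in the hydrogen-bond donor present only on 1H-pyrrol-2-yl, so a swap between rings of equal size is not neutral here. No measurement available on the series accounts for the step.

This single pair cannot separate the change of hetero atom from the loss of the donor. Furan-2-yl or 1-methyl-1H-pyrrol-2-yl on the same carbonyl carbon would bear on that, and it remains open whether the step carries over to the core of compound 1.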